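A few compounds are considered here, and "the series" means these few. Any claim that something is new, unique, unknown or untested is made for them only; others in the source may bear on it.

In an ADME assay on L1210/0 cells (Mus musculus) for cytotoxicity, with a stated time of 48 h (a lower number here means a stronger inhibitor, a higher number a weaker inhibitor), compound 1 `OC[C@H]1C[C@@H](Cn2cnc3c(-c4ccc(Cl)cc4)ncnc32)c2ccccc21` gives 8440 nM, the lower of the two numbers in hand, and compound 2 `CO[C@@H]1OC(n2cc(F)c(=O)[nH]c2=O)[C@H](OC(C)=O)[C@@H](OC(C)=O)[C@H]1F` gives 34000 nM, a gap beyond the scatter. Compound 3 `Nc1ncnc2c1ncn2C[C@@H]1C[C@H](CO)c2ccccc21` keeps the core of compound 1, with amino in place of 4-chlorophenyl on an aromatic carbon. Among the compounds with values here, no measured step covers this change, so the expectation rests on the structural change alone, starting from compound 1 at 8440 nM. A step beyond the scatter towards a higher number, meaning a weaker inhibitor, is expected: a 4.7-fold higher number from compound 1 to compound 3 (0.68 log units; beyond the scatter). Compound 3 is estimated at 40000 nM, with an expected range of 12000 nM to 130000 nM.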

Compound 3, half-maximal inhibitory concentration: > 200000 nM
Compound 3: a limit, no number; the forecaster's own chance of this, stated with the estimate: 35%; middle value at least 5.0-fold (0.69 log units) from the limit.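

In this assay, within the data shown here, amino in place of 4-chlorophenyl on this aromatic carbon gives an at least 23-fold higher number from compound 1 to compound 3 (1.37 log units; beyond the scatter), the only single-place comparison, so the group at this position matters for the read-out. The reading for compound 3 is a limit of the assay and not a number: the limit of > 200000 nM in this assay, at which 1 of the 3 values shown sits.

The change removes an aromatic ring and adds a hydrogen-bond donor at once, and compound 1 and compound 3 cannot separate the two. An unsubstituted phenyl or a methoxy group on this carbon would bear on that question.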